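The source may report more compounds than this note shows. Statements on the series, on what has been measured and on what is new or still open speak of the compounds shown alone.

Compound 1, `COc1cc2c(cc1OC)C(CC(N)=O)CC2`, gives 18.8% in a functional assay on the whole organism (strain Wistar) for inhibition, with Rattus norvegicus as the target, read by paw edema, with stated times of 60 min and 1 h, at a dose of 100 mg/kg by the oral route; on this read-out higher numbers stand for more inhibition at the one dose given (going by the name of the read-out) and lower numbers for less inhibition.
Compound 2, `CCCNC(=O)CC1CCc2cc(OC)c(OC)cc21`, gives 18.8% in this assay.
Compound 3, `CCCCCNC(=O)CC1CCc2cc(OC)c(OC)cc21`, gives 34.4% in this assay.

Compound 3 stands highest of the three numbers: the step of a number 15.6 percentage points higher from compound 1 to compound 3 (beyond the scatter) and the step of a number 15.6 percentage points higher from compound 2 to compound 3 (beyond the scatter) both lie beyond the scatter, while the step of no change at the digits printed from compound 1 to compound 2 (within the scatter) does not. Compound 4, `CCCCCCNC(=O)CC1CCc2cc(OC)c(OC)cc21`, carries the change (methyl in place of hydrogen on a saturated chain carbon, five bonds along the chain from an amide-type nitrogen). The step that bears most directly on this is a number 15.6 percentage points higher from compound 2 to compound 3 (beyond the scatter), where the chain on the amide-type nitrogen grew from propyl to pentyl and the read-out rose modestly; the step of no change at the digits printed from compound 1 to compound 2 (within the scatter) shows that the first addition of a propyl chain gave no change beyond the scatter. Growing the chain by one more methyl is a smaller change than either of these, so compound 4 is expected to give a step of a number 4.6 percentage points higher from compound 3 to compound 4 (within the scatter) in this assay, a rise of small size that may well stay within the scatter. Compound 4 is therefore estimated at 39% in this assay, with a range from 22% to 56%.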

Compound 4, a percentage reported as inhibition, in the whole organism at one dose (the size of the read-out at that dose, not a potency): 47.6%
Compound 4: the middle estimate sits 8.6 percentage points below what was measured; the measured number falls inside the stated range.
By their numbers in this assay, from the lowest: compounds 1 and 2 (each within the scatter of the next); then compound 3; then compound 4.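

The single methyl added here still counts: the step is a number 13.2 percentage points higher from compound 3 to compound 4 (beyond the scatter) in this assay, so the change on a saturated chain carbon, five bonds along the chain from an amide-type nitrogen, is not lost in the noise. Hexyl on the amide-type nitrogen gives the widest gaps in the set, with a number 28.8 percentage points higher from compound 2 to compound 4 (beyond the scatter) against the propyl amide and a number 28.8 percentage points higher from compound 1 to compound 4 (beyond the scatter) against the unsubstituted amide. From compound 2 through compound 3 to compound 4 the number climbs as the chain grows, while compound 2 goes against any simple rise, as its value does not separate from that of compound 1.

On these data alone, whether the rise carries on to a heptyl or longer chain, or survives an amine or carboxylic acid on the chain, stays open. Nothing available explains why the hexyl chain gives this gain.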